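The source may hold more compounds than are shown below. What is called first, only, known or untested is meant among the compounds shown, and "the series" means these compounds.

Working notes on the series. Compound 1 `Clc1ccc(CO/N=C/c2c(-c3ccc4ccccc4c3)nc3sccn23)cc1Cl` in an assay on HepG2 cells for agonist activity at nuclear receptor subfamily 1 group I member 3 (Homo sapiens), read by a luciferase reporter, with a stated time of 23 h (on this read-out higher numbers stand for an effect only at larger amounts of compound and lower numbers for an effect already at smaller amounts), gives 380 nM, the lowest of the three numbers in hand and beyond the scatter from both other measured compounds. Compound 2 `Clc1ccc(CO/N=C/c2c(-c3ccc4ccccc4c3)nc3occn23)c(Cl)c1` gives 1500 nM and compound 3 `Fc1c(F)c(F)c(CO/N=C/c2c(-c3ccc4ccccc4c3)nc3occn23)c(F)c1F` gives 1700 nM. For the measured compounds named here, the only step between measured compounds that differ in one place is a 1.1-fold higher number from compound 2 to compound 3 (0.05 log units; within the scatter); it concerns the group on the saturated chain carbon bound to an oxygen on an unsaturated carbon and leaves the group on the aromatic carbon of the core untouched.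

Compound 4 `Clc1ccc(CO/N=C/c2c(-c3ccc(Br)cc3)nc3sccn23)cc1Cl` is not yet measured. It differs from compound 1 as follows: 4-bromophenyl in place of naphthalen-2-yl on an aromatic carbon. Going by the values given here, no measured step bears on this change: compound 2 and compound 3 both carry the same naphthalen-2-yl as compound 1, so nothing in hand shows what exchanging that group does. Among the compounds with values here, the step in this assay from compound 1 to compound 4 therefore has no measured precedent; the expectation is a number near that of compound 1, leaning if anything toward a higher number, with a wide range on either side, which is the expected 2.1-fold higher number from compound 1 to compound 4 (0.32 log units; beyond the scatter). For compound 4 in this assay the estimate is 800 nM, with a range from 200 nM to 3000 nM.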

Compound 4, half-maximal effective concentration: 480 nM
For compound 4 the middle estimate is 1.7-fold (0.22 log units) above the measured one; low and high end bracket the measured number.
By their numbers in this assay, from the lowest: compounds 1 and 4 (each within the scatter of the next); then compounds 2 and 3 (each within the scatter of the next).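

In this assay, for the compounds shown here, the exchange on an aromatic carbon of a five-membered aromatic ring with 2 nitrogen gives a 1.3-fold higher number from compound 1 to compound 4 (0.10 log units; within the scatter), so this is the first reading at this position, which compounds 2 and 3 left unchanged. Going from naphthalen-2-yl, with 2 six-membered aromatic rings of carbon only and 10 heavy atoms, to 4-bromophenyl, with one such ring and 7 heavy atoms, leaves the number within the scatter, so in this pair the second aromatic ring of naphthalen-2-yl is not required to keep the number close to that of compound 1. Nothing in hand gives a reason why the two groups read so closely.

This single pair cannot separate the loss of the second ring from the arrival of the bromine, and plain phenyl, 4-chlorophenyl or a phenyl ring carrying an amine or a carboxylic acid at this position would test how far the tolerance extends. Going by these compounds, it also remains open whether 4-bromophenyl in place of naphthalen-2-yl reads the same way on the core of compound 2 and compound 3.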